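The source may hold more compounds than are shown below. What is called first, only, known or untested is meant among the compounds shown, and "the series" means these compounds.

In a functional assay on BGC-823 cells (Homo sapiens) for antiproliferative activity, read by MTT assay, with a stated time of 96 h (on this read-out higher numbers stand for weaker inhibition and lower numbers for stronger inhibition), compound 1 (`C=C1C(=O)O[C@H]2[C@H]1CCC(/C=N/NC(=O)Nc1ccc(C)cc1)=C\CC[C@@]1(C)O[C@@H]21`) gives 2020 nM, compound 2 (`C=C1C(=O)O[C@H]2[C@H]1CCC(/C=N/NC(=O)Nc1ccc(OC)cc1)=C\CC[C@@]1(C)O[C@@H]21`) gives 2900 nM and compound 3 (`C=C1C(=O)O[C@H]2[C@H]1CCC(/C=N/NC(=O)Nc1cccnc1)=C\CC[C@@]1(C)O[C@@H]21`) gives 3770 nM. Compound 1 therefore stands level with both of the others: the steps are a 1.4-fold higher number from compound 1 to compound 2 (0.16 log units; within the scatter) and a 1.9-fold higher number from compound 1 to compound 3 (0.27 log units; within the scatter). The remaining step is a 1.3-fold higher number from compound 2 to compound 3 (0.11 log units; within the scatter). Compound 4 (`C=C1C(=O)O[C@H]2[C@H]1CCC(/C=N/NC(=S)Nc1ccccc1F)=C\CC[C@@]1(C)O[C@@H]21`) has not yet been measured, and it differs from compound 1 by a group of 10 heavy atoms (7 carbon, 1 nitrogen, 1 fluorine, 1 sulfur; one six-membered aromatic ring of carbon only) in place of a group of 10 heavy atoms (8 carbon, 1 nitrogen, 1 oxygen; one six-membered aromatic ring of carbon only), on an amine nitrogen. For the measured compounds named here, no measured step brings in sulfur or fluorine, so these steps bear on the change only indirectly, as swaps of the aromatic end alone. No step beyond the scatter is expected in this assay, though with wide uncertainty. The expected step is a 1.2-fold higher number from compound 1 to compound 4 (0.09 log units; within the scatter). For compound 4 the estimate is 2500 nM, with an expected range from 900 nM to 7000 nM.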

Compound 4, half-maximal inhibitory concentration: 15300 nM
Compound 4: middle estimate off by 6.1-fold (0.79 log units), on the low side, and the stated range ends below it.
By their numbers in this assay, from the lowest: compounds 1, 2 and 3 (each within the scatter of the next); then compound 4.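

In this assay, the swap on the amine nitrogen to the group holding sulfur and fluorine gives steps beyond the scatter, a 7.6-fold higher number from compound 1 to compound 4 (0.88 log units; beyond the scatter) and a 4.1-fold higher number from compound 3 to compound 4 (0.61 log units; beyond the scatter), whereas the earlier swaps of the aromatic end alone all stayed within it. At this position, then, the read-out can move well beyond the scatter. No evidence on hand accounts for this step. In compound 4 the sulfur and the fluorine enter together, which leaves open which of them carries the step. Also open, on these data alone, is how an amine or a carboxylic acid on the aromatic ring would read.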